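The source may report more compounds than this note shows. Statements on the series, on what has been measured and on what is new or still open speak of the compounds shown alone.

Measured so far:
compound 1 `O=C(O)Cc1sc(C(c2ccc(F)cc2)c2ccc(F)cc2)nc1-c1ccnc(N2CCCC2)c1` — > 100000 nM
compound 2 `COc1ccc(C(c2ccccc2)c2nc(-c3ccc(Cl)cc3)c(CC(=O)O)s2)cc1` — 76 nM

In an in vitro functional assay on HEK285-7 cells for antagonist activity at prostaglandin D2 receptor 2 (Homo sapiens), read by BRET and beta-arrestin recruitment (on this read-out lower numbers stand for stronger inhibition and higher numbers for weaker inhibition), compound 1 gives > 100000 nM, which is a limit of the assay and not a number. Compound 1 therefore stands at the limit of > 100000 nM in this assay, at which 1 of the 2 values shown sits, and no finite reading places it among the measured compounds. In this assay compound 2 gives 76 nM. Among the measured compounds shown here, compound 2 differs from compound 1 in several places at once, so the pair forms no single step; the two values show only that a finite reading is reachable on this core.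

Compound 3 `Cc1cc(-c2nc(C(c3ccc(F)cc3)c3ccc(F)cc3)sc2CC(=O)O)ccn1` is not yet measured. It differs from compound 1 at one place: methyl in place of pyrrolidin-1-yl on an aromatic carbon. Cut one bond further out, 2-(pyrrolidin-1-yl)pyridin-4-yl becomes 2-methylpyridin-4-yl.

Because compound 1 shows only (the limit of > 100000 nM in this assay, at which 1 of the 2 values shown sits), the step from it has no numerical anchor. The expectation is a move toward stronger inhibition, an at least 33-fold lower number from compound 1 to compound 3 (1.52 log units; beyond the scatter), of uncertain size and with a real chance that only a limit is reported again. For compound 3 the estimated value in this assay is 3000 nM, with a range from 200 nM to 50000 nM.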

Compound 3, half-maximal inhibitory concentration: 53 nM
Compound 3: middle estimate off by 57-fold (1.75 log units), on the high side; the whole stated range lies above it.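

In this assay, exchanging 2-(pyrrolidin-1-yl)pyridin-4-yl for 2-methylpyridin-4-yl gives an at least 1800-fold lower number from compound 1 to compound 3 (3.27 log units; beyond the scatter), so on the core of compound 1 this one place, next to the ring nitrogen, separates a reading at the assay limit from a finite reading. For compound 1, the reading of > 100000 nM is a limit of the assay and not a number. The step is therefore a minimum and its full size remains unknown, because one end of it rests on that limit: the limit of > 100000 nM in this assay, at which 1 of the 3 values shown sits.

Still open, from the compounds shown here alone, is whether the change in reading belongs to the pyrrolidine ring specifically or would follow with any amine at this place, a question that a dimethylamino group or a morpholine ring there would address. Also open, going by these compounds, is how much of the finite reading depends on the methyl itself, which a plain hydrogen, an ethyl chain or a methoxy group at the same carbon would help to settle.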